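This account rests on a few compounds, and the source may have more. Where it says the series, first, only, none or still open, it means among the compounds named here.

Compound 1 `CC1=NN(C(=O)CCl)C(c2cc(F)ccc2O)C1`: 7000 nM
Compound 2 `CC1=NN(S(=O)(=O)c2ccccc2)C(c2cc(Br)ccc2O)C1`: 55600 nM

In a functional assay on SGC-7901 cells (Homo sapiens) for antiproliferative activity, read by MTT assay, with a stated time of 48 h (on this read-out lower numbers stand for an effect already at smaller amounts and higher numbers for an effect only at larger amounts of compound), compound 2 gives 55600 nM, the higher of the two numbers, and compound 1 sits lower at 7000 nM, a gap beyond the usual scatter. Compound 3 `CC1=NN(S(=O)(=O)c2ccc(Cl)cc2Cl)C(c2cc(Br)ccc2O)C1` keeps the rest of compound 2 and makes one change 2,4-dichlorophenyl in place of phenyl on a sulfonyl sulfur. Among the measured compounds shown here, no measured pair shows this swap, so any forecast in this assay is uncertain. A modest move towards a lower number is expected, an estimated 2.2-fold lower number from compound 2 to compound 3 (0.35 log units; beyond the scatter). Compound 3 is estimated at 25000 nM, within a range of 6000 nM to 90000 nM.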

Compound 3, half-maximal effective concentration: > 60000 nM
Compound 3: only a limit was reported; the forecaster's own chance of this, stated with the estimate: 10%; at least 2.4-fold (0.38 log units) between middle value and limit.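

In this assay compound 3 gives > 60000 nM, which is a limit of the assay and not a number: the limit of > 60000 nM in this assay, at which 1 of the 3 values shown sits. The step reads an at least 1.0-fold higher number from compound 2 to compound 3 (0.03 log units; that floor lies within the scatter), so 2,4-dichlorophenyl on this sulfonyl sulfur brought no move towards a lower number. Among the compounds shown here, this is the first view of a change at this position, though how far compound 3 lies from compound 2 stays unknown.

Open, as far as these compounds go, is whether a phenyl carrying an amine or a carboxylic acid would lower the number here. Compound 1 differs from compound 2 in more than one place, so its lower number cannot be traced to any single change.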